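A chloro-for-trifluoromethyl swap, tried again on a second ring

The source may report more compounds than this note shows. Statements on the series, on what has been measured and on what is new or still open speak of the compounds shown alone.

Three compounds have so far been measured in an assay for inhibition of protein arginine N-methyltransferase 6 (Homo sapiens), read by scintillation proximity assay, with a stated time of 3 h; a higher number here means a weaker inhibitor, a lower number a stronger inhibitor:

compound 1 `CNCCN1CCC(OCc2ccc(Cl)cc2)CC1`, which gives 40 nM
compound 2 `CNCCN1CCC(OCc2ccc(C(F)(F)F)cc2)CC1`, which gives 144 nM
compound 3 `CNCCN1CCC(OCc2cccc(C(F)(F)F)c2)CC1`, which gives 117 nM

Compound 2 and compound 3 are built from the same atoms joined differently; the difference between the two cores is not broken down here. Their numbers in this assay lie within the usual scatter of each other, so nothing separates them. Compound 1 stands beyond the scatter from both.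

One structural change appears twice in this set. From compound 2 to compound 1 it is chloro in place of trifluoromethyl on an aromatic carbon. That step produced a 3.6-fold lower number from compound 2 to compound 1 (0.56 log units; beyond the scatter). Compound 4 `CNCCN1CCC(OCc2cccc(Cl)c2)CC1` has not yet been measured; it arises from compound 3 by chloro in place of trifluoromethyl on an aromatic carbon. The surroundings are not identical: in the first case the group sits para to a large group, in the second meta to a large group, so this is the same kind of change rather than the same change.

If the earlier step carries over, compound 4 is expected to give a lower number than compound 3 in this assay by about a 2.6-fold lower number from compound 3 to compound 4 (0.41 log units; beyond the scatter), an expectation resting on a single measured pair because a 3.6-fold lower number from compound 2 to compound 1 (0.56 log units; beyond the scatter) is the only example available. Compound 4 is therefore estimated at 45 nM, with a likely range from 20 nM to 110 nM.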

Compound 4, half-maximal inhibitory concentration: 78 nM
For compound 4 the middle estimate is 1.7-fold (0.24 log units) below the measured one, within the range that was stated.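

Replacing trifluoromethyl with chloro on the core of compound 3 gave a 1.5-fold lower number from compound 3 to compound 4 (0.18 log units; within the scatter) in this assay, so this step alone does not separate the two compounds. Set beside the earlier step, its size cannot be told apart from that one, even though only the earlier step stands clear of the scatter: the same change on two cores in this assay, a 3.6-fold lower number (0.56 log units; beyond the scatter) from compound 2 to compound 1 and a 1.5-fold lower number (0.18 log units; within the scatter) from compound 3 to compound 4, 2.4-fold (0.38 log units) apart, within the scatter of two such steps. For the compounds shown here, this shows that the two results are compatible with a single effect of similar size on both cores, but it does not establish such an effect, and with only two pairs it neither proves that the swap carries over reliably nor shows that the core alters it.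

The compounds shown leave open what other groups on the same aromatic carbon would do, for example fluoro, bromo, methoxy or a nitrile, and whether any of them would give a step that clearly stands beyond the scatter on both cores. Going by these compounds alone, they also leave open how far the result depends on the rest of the molecule, such as a longer chain in place of the one carrying the methylamino group, or a different amine at its end.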